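A few compounds are considered here, and "the series" means these few. Any claim that something is new, unique, unknown or untested is made for them only; others in the source may bear on it.

Of the compounds shown here, three sharing one core have been measured in a physicochemical assay for solubility, with a stated time of 18 h, at pH 7.4; a higher number here means a more soluble compound, a lower number a less soluble compound. Compound 1 `CC(C)Cc1ccc2c(NCCCNCc3ccco3)ccnc2c1` gives 4200 nM; compound 2 `COc1cccc(CNCCCNc2ccnc3cc(CC(C)C)ccc23)c1O` gives 4200 nM; compound 3 `COc1ccc(F)cc1CNCCCNc1ccnc2cc(CC(C)C)ccc12` gives 4200 nM. The steps of no change at the digits printed from compound 1 to compound 2 (within the scatter), no change at the digits printed from compound 1 to compound 3 (within the scatter) and no change at the digits printed from compound 2 to compound 3 (within the scatter) all stay within the scatter, so compound 2 stands level with compounds 1 and 3 on the numbers shown. Compound 4 `COc1cccc(CNCCCNc2ccnc3cc(-c4cccc5ccccc45)ccc23)c1O` has not yet been measured. It differs from compound 2 as follows: naphthalen-1-yl in place of isobutyl on an aromatic carbon. Among the measured compounds shown here, none of the measured steps touches that part of the shared core; all three exchange only the group on the saturated chain carbon bound to the amine nitrogen, and each left the solubility where it was. For the measured compounds named here, no measured step therefore bears directly on this change, and the expectation rests on the size of the exchange itself, which is larger than any of the three measured ones. Compound 4 is expected to come out less soluble, with an estimated step of a 5.3-fold lower number from compound 2 to compound 4 (0.72 log units; beyond the scatter). The solubility of compound 4 in this assay is estimated at 800 nM, within a range from 150 nM to 3000 nM.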

Compound 4, solubility: 32000 nM
The estimate for compound 4 lay 40-fold (1.60 log units) below the measured number; the measured number lies above the stated range.
By their numbers in this assay, from the lowest: compounds 1, 2 and 3 (each within the scatter of the next); then compound 4.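

In this assay, the aromatic carbon carrying the isobutyl group proves responsive where the saturated chain carbon did not: naphthalen-1-yl in place of isobutyl gives a 7.6-fold higher number from compound 2 to compound 4 (0.88 log units; beyond the scatter), while all three earlier exchanges stayed within the scatter. The entering group has 10 heavy atoms and 2 six-membered aromatic rings of carbon only, against 4 heavy atoms and no ring for isobutyl, yet the number went up, a single pair that sets no general rule. Nothing presented here explains this rise.

From the compounds shown here alone, whether the rise is particular to naphthalen-1-yl or extends to other groups on this aromatic carbon remains open. A phenyl group, a morpholine or a carboxylic acid at the same place would show how far it extends, and whether it holds with the other chain-end groups is equally unsettled.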